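The compounds below may be only part of what the source reports. "The series", "measured", "known", "first", "only" and "open" are said of these compounds alone.

In an ADME assay on L1210/0 cells (Mus musculus) for cytotoxicity, with a stated time of 48 h (a higher number here means a weaker inhibitor, a lower number a stronger inhibitor), compound 1 `OC[C@H]1C[C@@H](Cn2cnc3c(-c4ccc(Cl)cc4)ncnc32)c2ccccc21` gives 8440 nM. Compound 2 `CCCNc1ncnc2c1ncn2C[C@@H]1C[C@H](CO)c2ccccc21` gives > 200000 nM, which is a limit of the assay and not a number. Compound 2 therefore stands at the limit of > 200000 nM in this assay, at which 1 of the 2 values shown sits.

Compound 3 `COc1ncnc2c1ncn2C[C@@H]1C[C@H](CO)c2ccccc21` keeps the shared core and carries methoxy in place of propylamino on an aromatic carbon. Within the data shown here, only one measured step bears on this change: an at least 23-fold higher number from compound 1 to compound 2 (1.37 log units; beyond the scatter). That step is large and beyond the scatter, and it comes with propylamino in place of 4-chlorophenyl on an aromatic carbon. It shows that a swap of this group can move the number a long way, but it says nothing directly about methoxy.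

Compound 2 has no number to start from, so the size of the next step in this assay is uncertain. A moderate move toward a lower number is expected, and compound 3 may well remain at the limit too. The expected change is an at least 2.0-fold lower number from compound 2 to compound 3 (0.30 log units; that floor lies within the scatter). Compound 3 is estimated at 100000 nM, with an expected range from 25000 nM to 200000 nM.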

Compound 3, half-maximal inhibitory concentration: > 200000 nM
Compound 3 ended at the assay's limit; the forecaster's own chance of this, stated with the estimate: 45%; at least 2.0-fold (0.30 log units) between middle value and limit.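

In this assay, compound 3 also ends at a limit of the assay and not at a number, so methoxy joins propylamino on this aromatic carbon, and the change of group gives no readable value. Among these compounds, replacing 4-chlorophenyl with methoxy gives an at least 23-fold higher number from compound 1 to compound 3 (1.37 log units; beyond the scatter), a large step beyond the scatter that matches the one printed for propylamino, so among the three compounds only the one with 4-chlorophenyl at this position has a measured number. The step between the two limit compounds cannot be read, so neither group can be ranked against the other, and the result adds a second compound to those at the top of the range: the limit of > 200000 nM in this assay, at which 2 of the 3 values shown sit.

The compounds shown leave open whether it is the 4-chlorophenyl group as a whole or its chlorine that separates compound 1 from the others, which an unsubstituted phenyl or a 4-methoxyphenyl on the same carbon would address. They also leave open whether a different kind of group at this position, such as a chlorine atom, a dimethylamino group or a longer alkyl chain, would bring the number back within the assay's range.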